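Acyl Chain Growth on Two Isothiocyanate Cores

The compounds below may be only part of what the source reports. "The series", "measured", "known", "first", "only" and "open" are said of these compounds alone.

Compound 1 `CC(=O)Nc1nc(CN=C=S)cs1`: 5200 nM
Compound 2 `CCC(=O)Nc1nc(CN=C=S)cs1`: 6800 nM
Compound 3 `CC(C)C(=O)Nc1nc(CN=C=S)c[se]1`: 28000 nM

In a functional assay on L1210 cells (Mus musculus) for antiproliferative activity (a lower number here means a stronger inhibitor, a higher number a weaker inhibitor), compound 1 gives 5200 nM and compound 2 gives 6800 nM. The change between them, (methyl in place of hydrogen on a saturated chain carbon bound to a carbonyl carbon), produced a 1.3-fold higher number from compound 1 to compound 2 (0.12 log units; within the scatter). Compound 3 gives 28000 nM; how its core differs from the core of compound 1 is not broken down here. Compound 4 `CC(C)(C)C(=O)Nc1nc(CN=C=S)c[se]1` has not been measured. It differs from compound 3 by methyl in place of hydrogen on a saturated chain carbon bound to a carbonyl carbon and two saturated chain carbons, the same kind of change as between compound 1 and compound 2, but here the carbon that receives the methyl is also bound to two saturated chain carbons, not to the carbonyl carbon alone. Resting on a 1.3-fold higher number from compound 1 to compound 2 (0.12 log units; within the scatter), which stayed within the scatter, a similarly small step is expected for compound 4, a 1.1-fold higher number from compound 3 to compound 4 (0.06 log units; within the scatter). The estimate for compound 4 is 32000 nM, expected to fall between 15000 nM and 70000 nM.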

Compound 4, half-maximal inhibitory concentration: 18000 nM
Beside the measured number, compound 4's estimate is 1.8-fold (0.25 log units) above it; the range from low to high includes it.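

In this assay, the change from isopropyl to tert-butyl gave a 1.6-fold lower number from compound 3 to compound 4 (0.19 log units; within the scatter), so the step stayed small on this second core as well. Set beside the earlier step, the change reads alike on both cores: the same change on two cores in this assay, a 1.3-fold higher number (0.12 log units; within the scatter) from compound 1 to compound 2 and a 1.6-fold lower number (0.19 log units; within the scatter) from compound 3 to compound 4, 2.0-fold (0.31 log units) apart, within the scatter of two such steps. Among these compounds, this shows that, for these two pairs, adding the methyl left the number within the scatter on either core, but it does not show that the two cores respond identically, and it rests on only two pairs in which the carbon receiving the methyl differs.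

The compounds shown leave open whether a longer chain or an amine on the acyl group would also leave the number little changed. From the compounds shown here alone, how the two cores compare under one and the same acyl group also stays open.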